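Carbamate for bromobenzamide on the hydroxamate series

This account rests on a few compounds, and the source may have more. Where it says the series, first, only, none or still open, it means among the compounds named here.

In a functional assay on NFF cells (Homo sapiens) for antiproliferative activity (on this read-out higher numbers stand for weaker inhibition and lower numbers for stronger inhibition), compound 1 `O=C(CCCCC[C@H](NC(=O)OCc1ccccc1)C(=O)NCc1ccccc1)NO` gives 1520 nM. For the measured compounds named here, compound 2 `O=C(CCCCC[C@H](NC(=O)c1ccc(Br)cc1)C(=O)NCc1ccncc1)NO` gives 5240 nM in this assay, the highest of the two numbers known, beyond the scatter from compound 1. Compound 3 `O=C(CCCCC[C@H](NC(=O)OCc1ccccc1)C(=O)NCc1ccncc1)NO` is not yet measured. Compound 3 differs from compound 2 in one place: benzyloxy in place of 4-bromophenyl on a carbonyl carbon. Going by the values given here, no measured pair shows this change directly; compound 1 carries the benzyloxy as well, so a move toward lower numbers is expected in this assay, a step of a 2.4-fold lower number from compound 2 to compound 3 (0.38 log units; beyond the scatter). For compound 3 the expected value in this assay is 2200 nM, with a range from 900 nM to 5500 nM.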

Compound 3, half-maximal inhibitory concentration: 23300 nM
For compound 3 the middle estimate is 11-fold (1.02 log units) below the measured one; measured number above the stated range.
By their numbers in this assay, from the lowest: compound 1; then compound 2; then compound 3.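

In this assay, benzyloxy on a carbonyl carbon does not carry a gain over 4-bromophenyl in the pyridin-4-yl setting, with a 4.4-fold higher number from compound 2 to compound 3 (0.65 log units; beyond the scatter) beyond the scatter. With benzyloxy held, pyridin-4-yl in place of phenyl gives the larger move, a 15-fold higher number from compound 1 to compound 3 (1.19 log units; beyond the scatter), so the change on the saturated chain carbon weighs more than the change on the carbonyl carbon in these compounds. Nothing available explains either step. Open, as far as these compounds go, is whether the pyridin-4-yl penalty persists with 4-bromophenyl on the carbonyl carbon, and how a piperidine or a carboxylic acid in place of the pyridin-4-yl would read.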